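The source may hold more compounds than are shown below. What is called first, only, known or untested is meant among the compounds shown, and "the series" means these compounds.

Measured in a functional assay on HL-60 cells (Homo sapiens) for antiproliferative activity, read by sulforhodamine B assay, with a stated time of 48 h; on this read-out lower numbers stand for stronger inhibition of growth and higher numbers for weaker inhibition of growth:
Compound 1 `COc1ccc(S(=O)(=O)c2nc3ccccc3cc2/C=C/C(=O)NO)cc1`: > 10000 nM, a limit of the assay and not a number
Compound 2 `O=C(/C=C/c1cccc(S(=O)(=O)c2ccc3ccccc3n2)c1)NO`: 290 nM
Compound 3 `O=C(/C=C/c1cccc(S(=O)(=O)c2ccc3cccc(F)c3n2)c1)NO`: 720 nM

Compound 1 gives only a limit, > 10000 nM, so it offers no number to reason from. Of the two actual numbers in this assay, the higher belongs to compound 3, at 720 nM. This makes it a weaker inhibitor of growth than compound 2, at 290 nM.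

Compound 4 `O=C(/C=C/c1cccc(S(=O)(=O)c2ccc3cccc(Cl)c3n2)c1)NO` keeps the rest of compound 3 and changes one group, with chloro in place of fluoro on an aromatic carbon. Among the compounds with values here, only one measured step bears on this same carbon: a 2.5-fold higher number from compound 2 to compound 3 (0.39 log units; beyond the scatter). That step is modest, although beyond the scatter, and it replaces hydrogen with fluoro. The exchange of fluoro for chloro itself has not been measured. On the strength of that single step, a small further move towards a higher number in this assay is expected, but not one that clearly leaves the scatter. The expected step is a 1.3-fold higher number from compound 3 to compound 4 (0.10 log units; within the scatter). For compound 4, the estimated value is 900 nM, with an expected range of 350 nM to 2300 nM.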

Compound 4, concentration for 50% growth inhibition: 2640 nM
Beside the measured number, compound 4's estimate is 2.9-fold (0.47 log units) below it; the whole stated range lies below it.
By their numbers in this assay, from the lowest: compound 2; then compound 3; then compound 4. At a limit, above all of these: compound 1.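

In this assay, within the data shown here, the halogen on this aromatic carbon matters more than the single step from hydrogen to fluoro could show, since exchanging fluoro for chloro gives a 3.7-fold higher number from compound 3 to compound 4 (0.56 log units; beyond the scatter), a second step beyond the scatter and in the same direction as the first. Measured against the hydrogen-bearing parent, chloro in place of hydrogen gives a 9.1-fold higher number from compound 2 to compound 4 (0.96 log units; beyond the scatter), so among these three compounds growth inhibition weakens in the order hydrogen, fluoro, chloro, and none of the three goes against that order. The measurements shown offer no explanation for this change.

On these data alone, what remains open is whether the same order would extend to bromo on this carbon, and whether a methoxy group or an amine there would read on the same side of the hydrogen-bearing compound in this assay. As far as these compounds go, it is also open whether chloro would weaken growth inhibition to a similar degree on another carbon of the same six-membered aromatic ring.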